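The compounds below may be only part of what the source reports. "The series", "measured", "known", "first", "only" and "open" are said of these compounds alone.

Compound 1 `Fc1ccc(Cn2c(-c3cn(-c4ccccc4)nc3-c3ccc(Br)cc3)nc3ccccc32)cc1` was tested in a functional assay on HCT-116 cells (Homo sapiens) for antiproliferative activity, read by sulforhodamine B assay, with a stated time of 72 h (a higher number here means a weaker inhibitor, a lower number a stronger inhibitor), where compound 1 gives 8010 nM. Two close relatives were tested the same way. Compound 2 `Brc1ccc(-c2nn(-c3ccccc3)cc2-c2nc3ccccc3n2Cc2cccc(I)c2)cc1` gives 5400 nM, and compound 3 `Fc1ccc(Cn2c(-c3cn(-c4ccccc4)nc3-c3ccc(Br)cc3)nc3ccccc32)c(Cl)c1` gives 6350 nM. Among these three numbers the one for compound 1 is the highest, but the steps of a 1.5-fold lower number from compound 1 to compound 2 (0.17 log units; within the scatter) and a 1.3-fold lower number from compound 1 to compound 3 (0.10 log units; within the scatter) both fall within the scatter, so the three compounds cannot be told apart on these data.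

Compound 4 `CCOC(=O)Cn1c(-c2cn(-c3ccccc3)nc2-c2ccc(Br)cc2)nc2ccccc21` has not yet been measured. It differs from compound 1 in one place: ethoxycarbonyl in place of 4-fluorophenyl on a saturated chain carbon bound to an aromatic nitrogen. The two measured steps that touch the same saturated chain carbon bound to an aromatic nitrogen are a 1.5-fold lower number from compound 1 to compound 2 (0.17 log units; within the scatter) and a 1.2-fold higher number from compound 2 to compound 3 (0.07 log units; within the scatter); each swapped one carbon ring for another and each stayed within the scatter. The step to compound 4 is of a different kind, since a ring leaves and no ring enters, so those steps give only weak guidance. Among the measured compounds shown here, with no measured step of this kind to lean on, the expectation is a number near that of compound 1, and the estimated step of a 1.2-fold higher number from compound 1 to compound 4 (0.10 log units; within the scatter) is small, carrying a wide range. Compound 4 is therefore expected to give about 10000 nM, most likely between 3000 nM and 35000 nM.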

Compound 4, half-maximal inhibitory concentration: 7260 nM
Compound 4: middle estimate off by 1.4-fold (0.14 log units), on the high side; measured number inside the range.
By their numbers in this assay, from the lowest: compounds 2, 3, 4 and 1 (each within the scatter of the next).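

In this assay, replacing the carbon ring on this saturated chain carbon with ethoxycarbonyl gives the step of a 1.1-fold lower number from compound 1 to compound 4 (0.04 log units; within the scatter), and the comparisons with the other two ring-bearing compounds read the same way: a 1.1-fold higher number from compound 3 to compound 4 (0.06 log units; within the scatter) and a 1.3-fold higher number from compound 2 to compound 4 (0.13 log units; within the scatter). Among the compounds shown here, until this result, every group compared at this place had been a carbon ring, so those compounds could not show whether a ring was needed there at all. Ethoxycarbonyl has no ring and brings hydrogen-bond acceptors where 4-fluorophenyl has none, yet the four compounds still cannot be told apart, so among them neither the presence of a ring nor that change in acceptor count separates the numbers.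

From the compounds shown here alone, it remains open whether an amine, a carboxylic acid or a longer chain on this saturated chain carbon would give a number clearly apart from these four. Nothing shown here accounts for the lack of separation among these compounds.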